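The source may hold more compounds than are shown below. What is called first, only, known or untested is meant among the compounds shown, and "the series" means these compounds.

Measured so far in an assay on mitochondria (strain BALB/c) for inhibition of glycerol-3-phosphate acyltransferase 1, mitochondrial (Mus musculus), read by scintillation counting, with a stated time of 10 min; on this read-out higher numbers stand for weaker inhibition and lower numbers for stronger inhibition:

- compound 1, `CCCCCCCCS(=O)(=O)Nc1ccc(/C=C/c2ccccc2)cc1C(=O)O`: 16300 nM
- compound 2, `CCCCCCCCS(=O)(=O)Nc1ccc(/C=C/c2ccc(OC)cc2)cc1C(=O)O`: 37100 nM
- compound 3, `CCCCCCCCS(=O)(=O)Nc1cc(CCc2ccccc2)ccc1C(=O)O`: 37500 nM

Compounds 1 and 2 share one core; compound 3 carries another. The difference between the two cores is not broken down here. Within the first core the one change made is methoxy in place of hydrogen on an aromatic carbon, at a place on an aromatic carbon of a six-membered aromatic ring of carbon only, para to a large group. The step it produced in this assay is a 2.3-fold higher number from compound 1 to compound 2 (0.36 log units; beyond the scatter), a modest loss of inhibition that nevertheless lies beyond the usual scatter.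

Compound 3 stands near compound 2, the two numbers within the scatter of each other, and gives a higher number than compound 1 by a gap beyond the scatter.

Not yet measured is compound 4, `CCCCCCCCS(=O)(=O)Nc1cc(CCc2ccc(OC)cc2)ccc1C(=O)O`. It is made from compound 3 by methoxy in place of hydrogen on an aromatic carbon, the same change at a place described in the same words as for the pair of compounds 1 and 2, now on the core of compound 3.

Among the measured compounds shown here, with only one earlier instance of this change, the expectation rests on compound 1 and compound 2 alone. The step from compound 3 to compound 4 is expected to be a 1.9-fold higher number from compound 3 to compound 4 (0.27 log units; within the scatter), in the same direction as the earlier one. Compound 4 is therefore estimated at 70000 nM in this assay, with a plausible range from 30000 nM to 160000 nM.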

Compound 4, half-maximal inhibitory concentration: 43000 nM
Compound 4: middle estimate off by 1.6-fold (0.21 log units), on the high side; measured number inside the range.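

Notes on the methoxy change: in this assay, methoxy in place of hydrogen on an aromatic carbon, para to a large group, gives a 1.1-fold higher number from compound 3 to compound 4 (0.06 log units; within the scatter) on the core of compound 3, a step that does not separate the two compounds. Set beside the earlier step on the core of compound 1, the new step cannot be told apart from it: the same change on two cores in this assay, a 2.3-fold higher number (0.36 log units; beyond the scatter) from compound 1 to compound 2 and a 1.1-fold higher number (0.06 log units; within the scatter) from compound 3 to compound 4, 2.0-fold (0.30 log units) apart, within the scatter of two such steps. Among the compounds shown here, this shows that nothing here speaks against the change carrying from one core to the other, but it does not show a shared effect, since only the step on the core of compound 1 lies beyond the scatter, and two pairs cannot distinguish a small, consistent loss of inhibition from a loss confined to one core.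

The compounds shown leave open how other groups at this same place would behave on the two cores, for example a hydroxyl, a fluorine or a trifluoromethyl in place of the methoxy. They also leave open whether the comparison would hold with an amide in place of the carboxylic acid or with a shorter chain on the sulfonyl group.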